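The compounds below may be only part of what the source reports. "The series", "measured", "known", "first", "only" and "open" are said of these compounds alone.

Measured in an ADME assay on a cell-free system (plasma, Homo sapiens) for protein binding; on this read-out lower numbers stand for a smaller free fraction and higher numbers for a larger free fraction:
Compound 1 `Cc1cc(C)c(-c2cn(C)cn2)cc1NC(=O)c1ccc(OCc2ccccn2)cc1`: 0.055
Compound 2 `Cc1cc(F)c(-c2ncc[nH]2)cc1NC(=O)c1ccc(OCc2ccccn2)cc1`: 0.11
Compound 3 `Cc1ccc(-c2ncc[nH]2)c(C)c1NC(=O)c1ccc(OCc2ccccn2)cc1`: 0.09

These three values all lie within the usual scatter of one another, so compound 1 does not stand apart from compound 2 or compound 3 on this read-out. Compound 4 `Cc1cc(C)c(-c2ccc(N)nn2)cc1NC(=O)c1ccc(OCc2ccccn2)cc1` has not yet been measured. It keeps the core of compound 1 but carries 6-aminopyridazin-3-yl in place of 1-methyl-1H-imidazol-4-yl on an aromatic carbon. For the measured compounds named here, no two measured compounds differ in one place only, so the data give no direct measure of a single change of this kind. The three measured compounds do differ from one another in structure, yet their values stay within the scatter. On that basis, only a small shift in this assay is expected, with a slight lean towards a larger free fraction and nothing beyond the scatter. The expected change is a 1.3-fold higher number from compound 1 to compound 4 (0.10 log units; within the scatter). For compound 4 the estimated value is 0.07, with an expected range from 0.035 to 0.14.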

Compound 4, unbound fraction: 0.064
Estimate against measurement, compound 4: 1.1-fold (0.04 log units) above; measured number inside the range.
By their numbers in this assay, from the lowest: compounds 1, 4, 3 and 2 (each within the scatter of the next).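

In this assay, for the compounds shown here, the one comparison that differs in a single place gives a 1.2-fold higher number from compound 1 to compound 4 (0.07 log units; within the scatter), so on this aromatic carbon, ortho to a methyl group and para to a methyl group, 6-aminopyridazin-3-yl and 1-methyl-1H-imidazol-4-yl cannot be told apart on this read-out. The two groups differ in ring size and in their counts of hydrogen-bond donors and acceptors, yet this exchange stays within the scatter. Nothing available here explains this outcome.

On these data alone, whether a quite different group on this carbon, such as a carboxylic acid or a primary amine directly on the ring, would also stay within the scatter remains open. As far as these compounds go, it is also open whether 6-aminopyridazin-3-yl would behave the same way on the cores of compound 2 and compound 3.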